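The compounds below may be only part of what the source reports. "The series", "measured", "known", "first", "only" and "open" are said of these compounds alone.

Measured so far, in a functional assay on MCF7 cells (Homo sapiens) for antiproliferative activity, read by sulforhodamine B assay, with a stated time of 48 h; on this read-out lower numbers stand for stronger inhibition and higher numbers for weaker inhibition:
compound 1 `CCCCCC(=O)Nc1cccc(S(=O)(=O)Oc2ccccc2C(C)C)c1` gives 12000 nM;
compound 2 `CCC(=O)Nc1ccc(S(=O)(=O)Oc2ccccc2C(C)C)cc1` gives 11000 nM;
compound 3 `CCC(=O)Nc1ccc(S(=O)(=O)Oc2ccccc2I)cc1` gives 8100 nM.

The three numbers sit close together. Compound 2 lies within the usual scatter of both compound 1 and compound 3, so none of the three can be set apart from the others on these measurements alone. Among the compounds with values here, the only single-point comparison among them is the one from compound 2 to compound 3, which reads a 1.4-fold lower number from compound 2 to compound 3 (0.13 log units; within the scatter); it concerns the group on the other aromatic ring, not the amide.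

Compound 4 `CC(C)c1ccccc1OS(=O)(=O)c1ccc(NC(=O)C(C)(C)C)cc1` is not yet measured. Compared with compound 2 the change is tert-butyl in place of ethyl on a carbonyl carbon. Within the data shown here, no measured pair differs at this carbonyl carbon alone, so there is no step on record that bears directly on this change; compound 1 carries a longer acyl chain but also differs from compound 2 in where the amide sits on its ring, and the two values are within the scatter of each other anyway.

With nothing pointing either way, the expected step from compound 2 to compound 4 is no change at the digits printed from compound 2 to compound 4 (within the scatter), that is, none beyond the scatter. The expectation for compound 4 in this assay is therefore 11000 nM, with a range from 5000 nM to 25000 nM.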

Compound 4, half-maximal inhibitory concentration: 6500 nM
Beside the measured number, compound 4's estimate is 1.7-fold (0.23 log units) above it, and the stated range covers the measured number.
By their numbers in this assay, from the lowest: compounds 4, 3, 2 and 1 (each within the scatter of the next).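

In this assay the carbonyl carbon of the amide now has its first direct comparison, and it reads a 1.7-fold lower number from compound 2 to compound 4 (0.23 log units; within the scatter) for tert-butyl, with its 4 carbons, in place of ethyl, with its 2. This position therefore accepts a group with two more carbons, branched at the point where it joins the carbonyl, without any loss of antiproliferative activity beyond the scatter; on this single pair, the measurements cannot separate the two groups in either direction. No supporting measurement is available to explain this result.

From the compounds shown here alone, one pair cannot show how far this acceptance extends, and it remains open whether a phenyl ring, an amine or a carboxylic acid attached at this carbonyl carbon would shift the number beyond the scatter. It is also open whether tert-butyl would behave in the same way alongside iodo in place of isopropyl on the other aromatic ring, since the compounds shown do not combine those two changes.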